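The source may hold more compounds than are shown below. What is called first, only, known or untested is meant among the compounds shown, and "the series" means these compounds.

Measured so far in an ADME assay on a cell-free system (plasma, Homo sapiens) for metabolic stability, with Plasma (Rattus norvegicus) as the target, read by HPLC; on this read-out lower numbers stand for a shorter-lived compound and higher numbers for a longer-lived compound:
compound 1 `COc1cc(NC(C)CCCN2C(=O)CN(C(=O)[C@H](N)CCSC)C2(C)C)c2ncccc2c1` — > 3 h
compound 2 `COc1cc(NC(C)CCCN2C(=O)CN(C(=O)CN)C2(C)C)c2ncccc2c1` — > 3 h

The value of compound 1 is only a limit of this assay. The value of compound 2 is likewise only a limit. Both sit at the limit of > 3 h in this assay, at which 2 of the 2 values shown sit, so the step that the two limits leave unreadable from compound 1 to compound 2 cannot be read in size. Compound 3 `COc1cc(NC(C)CCCN2C(=O)CN(C(=O)[C@H](N)C(C)C)C2(C)C)c2ncccc2c1` is not yet measured; it differs from compound 2 by isopropyl in place of hydrogen on a saturated chain carbon bound to an amine nitrogen and a carbonyl carbon. Within the data shown here, the one measured step bears on this change only in that both of its ends stay at the limit, so no size can be drawn from it. Compound 3 is expected to remain at that limit as well, estimated at 4 h with a range of 2.5 h to 8 h. The step that the limit leaves unreadable from compound 2 to compound 3 is thereby expected to stay within the scatter.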

Compound 3, half-life: > 3 h
Compound 3 was reported as a limit; the forecaster's own chance of this, stated with the estimate: 85%; the middle value does not contradict the limit.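

In this assay compound 3 gives > 3 h as a limit, not a number. Among these compounds, no step among compound 1, compound 2 and compound 3 can be read in size: the limit of > 3 h in this assay, at which 3 of the 3 values shown sit. From the compounds shown here alone, the actual half-lives of all three compounds, and any difference between them, remain open.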